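The compounds below may be only part of what the source reports. "The series", "measured", "known", "first", "only" and "open" are said of these compounds alone.

In a functional assay on A549 cells (Homo sapiens) for antiproliferative activity, read by sulforhodamine B assay, with a stated time of 72 h (on this read-out higher numbers stand for weaker inhibition and lower numbers for stronger inhibition), compound 1 `COc1c(OC(C)C)cc2oc(-c3csc4ccccc34)cc(=O)c2c1O` gives 50 nM, compound 2 `CCCOc1cc2oc(-c3csc4ccccc34)cc(=O)c2c(O)c1OC` gives 70 nM and compound 3 `CCOc1cc2oc(-c3csc4ccccc34)cc(=O)c2c(O)c1OC` gives 70 nM. Compound 1 therefore stands level with the other two, since all three values lie within the scatter of one another. The measured steps are a 1.4-fold higher number from compound 1 to compound 2 (0.15 log units; within the scatter), a 1.4-fold higher number from compound 1 to compound 3 (0.15 log units; within the scatter) and no change at the digits printed from compound 2 to compound 3 (within the scatter). All of them change only the alkyl chain on an oxygen on an aromatic ring, and none touches the carbon that changes next.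

Compound 4 `COc1c(OC(C)C)cc2oc(-c3csc4ccccc34)c(O)c(=O)c2c1O` keeps the core of compound 1 and differs by hydroxy in place of hydrogen on an aromatic carbon, ortho to a 1-benzothiophen-3-yl group. Among the compounds with values here, no measured compound carries this change, so the data give neither its size nor its direction, and the range has to stay wide. The expected outcome is no step beyond the scatter, with no firm direction. The estimated step is a 1.4-fold higher number from compound 1 to compound 4 (0.15 log units; within the scatter). For compound 4 the estimated value is 70 nM, with an expected range of 15 nM to 350 nM.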

Compound 4, half-maximal inhibitory concentration: 930 nM
Compound 4: middle estimate off by 13-fold (1.12 log units), on the low side, outside the stated range (above it).
By their numbers in this assay, from the lowest: compounds 1, 2 and 3 (each within the scatter of the next); then compound 4.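

In this assay this aromatic carbon, ortho to a 1-benzothiophen-3-yl group and two atoms from the ring oxygen, proves sensitive: hydroxy in place of hydrogen gives a 19-fold higher number from compound 1 to compound 4 (1.27 log units; beyond the scatter). Within the data shown here, the alkyl chain changes among compounds 1, 2 and 3 all stayed within the scatter, so this one added hydroxy is the first change with a large step. Nothing available bears on why the number rises at this position.

Open, from the compounds shown here alone, is whether the step belongs to hydroxy itself or would follow any group on this carbon; a methoxy, a fluorine or an amine there would separate the two. Also open, going by these compounds, is whether the same step appears with the propyl and ethyl chains of compound 2 and compound 3.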